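Working notes: compound 3 to compound 4

A few compounds are considered here, and "the series" means these few. Any claim that something is new, unique, unknown or untested is made for them only; others in the source may bear on it.

Measured in a functional assay on HCT-116 cells (Homo sapiens) for antiproliferative activity, read by MTT assay, with a stated time of 72 h; a lower number here means a stronger inhibitor, a higher number a weaker inhibitor:
- compound 1 `O=C(CCc1cccc2c1B(O)OC2)Nc1ccc(F)cc1`: 650 nM
- compound 2 `CC(C)(C)c1ccc(NC(=O)CCc2cccc3c2B(O)OC3)cc1`: 19000 nM
- compound 3 `CC(C)c1cccc(NC(=O)CCc2cccc3c2B(O)OC3)c1`: 1600 nM

Compound 3, at 1600 nM, stands second highest of the three numbers, with compound 1 lower and compound 2 higher. The next compound to be tested is compound 4 `O=C(CCc1cccc2c1B(O)OC2)Nc1cccc(-c2ccc(Cl)cc2)c1`. It carries 4-chlorophenyl in place of isopropyl on an aromatic carbon, meta to a large group: 4-chlorophenyl in place of isopropyl on an aromatic carbon.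

Among the compounds with values here, only one measured step changes a single place. With tert-butyl in place of fluoro on an aromatic carbon, it gave a 29-fold higher number from compound 1 to compound 2 (1.47 log units; beyond the scatter). This large step points towards a higher number when a bigger group enters. Within the data shown here, it is thin ground, however, as no measured step brings in an aromatic ring. The values of compound 1 and compound 3 also show that the series tolerates some substitution without reaching the level of compound 2.

A moderate move towards a higher number is therefore expected in this assay, smaller than the measured step, and the estimated step is a 2.5-fold higher number from compound 3 to compound 4 (0.40 log units; beyond the scatter). For compound 4 the estimated value is 4000 nM, with an expected range from 800 nM to 20000 nM.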

Compound 4, half-maximal inhibitory concentration: 380 nM
Compound 4: the middle estimate sits 11-fold (1.02 log units) above what was measured; the whole stated range lies above it.
By their numbers in this assay, from the lowest: compounds 4 and 1 (each within the scatter of the next); then compound 3; then compound 2.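

In this assay, on an aromatic carbon of a six-membered aromatic ring of carbon only, meta to a large group, 4-chlorophenyl in place of isopropyl gives a 4.2-fold lower number from compound 3 to compound 4 (0.62 log units; beyond the scatter) and so brings a lower number, even though the entering group has 7 heavy atoms against 3 and adds an aromatic ring. A larger group therefore does not always bring a higher number in this series: tert-butyl in place of fluoro gave a 29-fold higher number from compound 1 to compound 2 (1.47 log units; beyond the scatter) in the opposite direction, but the two steps share neither the leaving nor the entering group, so they yield no general rule on size. No measurement of any property bears on this result, and its cause remains unassigned.

The compounds shown leave open whether the aromatic ring or the chlorine accounts for the step, a question that phenyl without chlorine at the same place would address. They also leave open how the series responds to an amine or a carboxylic acid in place of the chlorine on the entering ring.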